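Notes on a glycine transporter series: thiazole for pyridine

A few compounds are considered here, and "the series" means these few. Any claim that something is new, unique, unknown or untested is made for them only; others in the source may bear on it.

Measured so far:
compound 1 `CCC(NC(=O)CNC(=O)c1ccc(F)cc1)c1ccccc1`; in an assay for inhibition of sodium- and chloride-dependent glycine transporter 1 (Homo sapiens) (a lower number here means that less compound is needed, a higher number that more compound is needed for the effect), compound 1 gives 4100 nM
compound 2 `O=C(CNC(=O)c1ccc(F)cc1)NC(c1ccccc1)c1ccncc1`; in this assay compound 2 gives 730 nM

Going by the values given here, compound 2 holds the lowest number of the two in this assay; the one measured step, a 5.6-fold lower number from compound 1 to compound 2 (0.75 log units; beyond the scatter), separates it from compound 1 and lies beyond the scatter.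

Compound 3 `O=C(CNC(=O)c1ccc(F)cc1)NC(c1ccccc1)c1nccs1` differs from compound 2 by 1,3-thiazol-2-yl in place of pyridin-4-yl on a saturated chain carbon bound to an amide-type nitrogen and an aromatic carbon. Among the compounds with values here, no measured step exchanges one aromatic ring for another at this carbon. Within the data shown here, the only step available, a 5.6-fold lower number from compound 1 to compound 2 (0.75 log units; beyond the scatter), replaced an ethyl with a pyridin-4-yl, so it shows that an aromatic ring carrying a nitrogen at this carbon is favourable, but says nothing about which such ring. The step to compound 3 keeps a nitrogen-containing aromatic ring at the same carbon, so in this assay a change within the scatter is expected, with the uncertainty leaning toward a higher number. Compound 3 is estimated at 1000 nM (range 350 nM to 3000 nM), which is expected to mean a 1.4-fold higher number from compound 2 to compound 3 (0.14 log units; within the scatter).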

Compound 3, half-maximal effective concentration: 5050 nM
Estimate against measurement, compound 3: 5.1-fold (0.70 log units) below, outside the stated range (above it).
By their numbers in this assay, from the lowest: compound 2; then compounds 1 and 3 (each within the scatter of the next).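

At the saturated chain carbon bound to an amide-type nitrogen and an aromatic carbon, the choice of aromatic ring matters in this assay: 1,3-thiazol-2-yl in place of pyridin-4-yl gives a 6.9-fold higher number from compound 2 to compound 3 (0.84 log units; beyond the scatter). Set against ethyl, 1,3-thiazol-2-yl gives a 1.2-fold higher number from compound 1 to compound 3 (0.09 log units; within the scatter), which is within the scatter, so among these three groups the lower number belongs to pyridin-4-yl alone and does not extend to every aromatic ring carrying a nitrogen. Nothing measured here accounts for the difference between the two rings.

The compounds shown leave open whether this result follows the size of the ring or the place of the ring nitrogen. Pyridin-3-yl, pyridin-2-yl or 1,3-oxazol-2-yl at this carbon would bear on that question.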